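Swapping a hydroxyethyl for fluorine on a receptor agonist

A few compounds are considered here, and "the series" means these few. Any claim that something is new, unique, unknown or untested is made for them only; others in the source may bear on it.

Measured compounds:
compound 1 `CC(O)c1cnc(N2CCC(c3coc4c(N5CCc6cc(S(C)(=O)=O)ccc65)ncnc34)CC2)nc1` gives 586 nM
compound 2 `CC(C)(C)OC(=O)N1CCC(c2coc3c(N4CC(C)(C)c5cc(S(C)(=O)=O)ccc54)ncnc23)CC1` gives "not active" (no number reported)

Going by the values given here, in a functional assay on cells for agonist activity at Glucose-dependent insulinotropic receptor (Homo sapiens), read by a luciferase reporter, with a stated time of 4 h (on this read-out higher numbers stand for an effect only at larger amounts of compound and lower numbers for an effect already at smaller amounts), compound 1 gives 586 nM, the only number in this set; compound 2 is reported as "not active" (no number reported) without a value. Compound 3 `CS(=O)(=O)c1ccc2c(c1)CCN2c1ncnc2c(C3CCN(c4ncc(F)cn4)CC3)coc12` differs from compound 1 by one change: fluoro in place of 1-hydroxyethyl on an aromatic carbon. Among the compounds with values here, no measured pair shows the effect of such a change here, so the step from compound 1 to compound 3 is expected to be small, likely within the usual scatter, with a slight lean toward weaker activity. Compound 3 is therefore estimated at 800 nM, within 250 nM to 3000 nM, meaning a step of a 1.4-fold higher number from compound 1 to compound 3 (0.14 log units; within the scatter).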

Compound 3, half-maximal effective concentration: 201 nM
Compound 3: middle estimate off by 4.0-fold (0.60 log units), on the high side, outside the stated range (below it).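

In this assay, replacing 1-hydroxyethyl with fluoro on the six-membered aromatic ring with 2 nitrogen gives a 2.9-fold lower number from compound 1 to compound 3 (0.46 log units; beyond the scatter). Activity at this position therefore does not depend on the 1-hydroxyethyl group or its hydrogen-bond donor, since a single fluorine atom, which has no donor, gives the lower number. Nothing measured here explains the shift. As far as these compounds go, it remains open how a chlorine atom, a nitrile, a methoxy group or an amine would behave at this carbon. This single pair also cannot show whether the same change would have a similar effect on a different core.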